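Adding a second trifluoromethyl group to compound 2

The source may report more compounds than this note shows. Statements on the series, on what has been measured and on what is new or still open speak of the compounds shown alone.

Measured in a functional assay on KB cells (Homo sapiens) for inhibition; a lower number here means a stronger inhibitor, a higher number a weaker inhibitor:
- compound 1 `Clc1cc2nc(Cl)n(Cc3ccccc3)c2cc1Cl`: > 100000 nM (a limit)
- compound 2 `FC(F)(F)c1cccc(Cn2c(Cl)nc3cc(Cl)c(Cl)cc32)c1`: > 100000 nM (a limit)

In this assay compound 2 stands at > 100000 nM, which is a limit and not a number. Among the compounds with values here, the series so far shows only (the limit of > 100000 nM in this assay, at which 2 of the 2 values shown sit). Compound 3 `FC(F)(F)c1cc(Cn2c(Cl)nc3cc(Cl)c(Cl)cc32)cc(C(F)(F)F)c1` carries one further change, trifluoromethyl in place of hydrogen on an aromatic carbon, meta to a trifluoromethyl group. Within the data shown here, the one measured exchange of the same kind is a step that the two limits leave unreadable from compound 1 to compound 2, and it offers no size to carry over. No step beyond the scatter is therefore expected in this assay, and no direction can be given. The expected step is a number no higher from compound 2 to compound 3 (the limit leaves the size open). Compound 3 is estimated at 100000 nM, with an expected range from 40000 nM to 200000 nM.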

Compound 3, half-maximal inhibitory concentration: > 100000 nM
Compound 3: a limit, no number; the forecaster's own chance of this, stated with the estimate: 85%; the middle value lies on the limit itself.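

In this assay compound 3 gives > 100000 nM, a limit and not a number. Within the data shown here, compound 2 also stands at a limit, so no step from compound 2 to compound 3 can be read. Left open is whether adding trifluoromethyl changes inhibition at all, and how far each compound lies from the shared limit: the limit of > 100000 nM in this assay, at which 3 of the 3 values shown sit.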